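Fluorine Placement on a Benzyl Group and Binding Potency

This account rests on a few compounds, and the source may have more. Where it says the series, first, only, none or still open, it means among the compounds named here.

Compound 1, `Cc1cc(Nc2nc(NCc3ccccc3F)nc3ccccc23)n[nH]1`, gives 110 nM in an assay for inhibition of high affinity nerve growth factor receptor (Homo sapiens), read by HTRF, with a stated time of 30 min, in the presence of a further agent that is not named here; on this read-out lower numbers stand for stronger inhibition and higher numbers for weaker inhibition.
Compound 2, `Cc1cc(Nc2nc(NCc3ccc(F)cc3F)nc3ccccc23)n[nH]1`, gives 200 nM in this assay.
Compound 3, `Cc1cc(Nc2nc(NCc3cc(F)cc(F)c3)nc3ccccc23)n[nH]1`, gives 170 nM in this assay.

All three share one core and differ only in the fluorines on the benzyl ring. Compound 2 differs from compound 1 by fluoro in place of hydrogen on an aromatic carbon, and that change brought a 1.8-fold higher number from compound 1 to compound 2 (0.26 log units; within the scatter). Compound 3 differs from compound 1 by 3,5-difluorophenyl in place of 2-fluorophenyl on a saturated chain carbon bound to a nitrogen on an aromatic ring, which gave a 1.5-fold higher number from compound 1 to compound 3 (0.19 log units; within the scatter). Between compound 2 and compound 3 the result was a 1.2-fold lower number from compound 2 to compound 3 (0.07 log units; within the scatter). All three numbers therefore lie within the usual spread of such measurements, and none of the compounds can be called stronger or weaker than another.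

Compound 4, `Cc1cc(Nc2nc(NCc3cc(F)c(F)c(F)c3)nc3ccccc23)n[nH]1`, has not yet been measured. It differs from compound 3 by fluoro in place of hydrogen on an aromatic carbon. Among the compounds with values here, this is the same kind of change as the one from compound 1 to compound 2, but the surroundings differ: there the new fluoro sat meta to a fluoro group, here it sits ortho to two fluoro groups, in both cases para to a large group. The step from compound 3 to compound 4 is expected to be a 1.3-fold higher number from compound 3 to compound 4 (0.11 log units; within the scatter) in this assay, a guess that rests on a 1.8-fold higher number from compound 1 to compound 2 (0.26 log units; within the scatter). Compound 4 is thus estimated at 220 nM, likely between 100 nM and 500 nM.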

Compound 4, half-maximal inhibitory concentration: 870 nM
Estimate against measurement, compound 4: 4.0-fold (0.60 log units) below, and the stated range ends below it.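

Compound 4 is the weakest of the four in this assay: placing a fluoro ortho to two fluoro groups gave a 5.1-fold higher number from compound 3 to compound 4 (0.71 log units; beyond the scatter), and the comparisons with the other two compounds show a 4.4-fold higher number from compound 2 to compound 4 (0.64 log units; beyond the scatter) and a 7.9-fold higher number from compound 1 to compound 4 (0.90 log units; beyond the scatter). The swap of hydrogen for fluoro therefore did not carry over with the same size from one fluorinated benzyl ring to the other, so the step seen first was a poor guide to the second: the same change on two cores in this assay, a 1.8-fold higher number (0.26 log units; within the scatter) from compound 1 to compound 2 and a 5.1-fold higher number (0.71 log units; beyond the scatter) from compound 3 to compound 4, 2.8-fold (0.45 log units) apart, beyond the scatter of two such steps. Within the data shown here, this shows that the size of the step depends on the ring that receives the fluoro, but with only two such steps it gives no general rule, and it does not show why the second step is larger or how the same change would behave on any other ring.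

All the compounds shown carry only fluoro groups on the benzyl ring and keep the same shared core and the same link to that ring. As far as these compounds go, it remains open whether a chloro, methyl or methoxy group in place of the added fluoro would give a step of similar size, and whether a longer chain in place of the benzyl link would change the picture.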